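This account rests on a few compounds, and the source may have more. Where it says the series, first, only, none or still open, it means among the compounds named here.

Measured compounds:
- compound 1, `CCCOC(=O)Nc1ccc([Se]C#N)cc1`: 68800 nM
- compound 2, `CCOC(=O)Nc1ccc([Se][Se]c2ccc(NC(=O)OCC)cc2)cc1`: 74300 nM
- compound 3, `N#C[Se]c1ccc(NC(=O)Oc2ccc(Cl)cc2)cc1`: 71800 nM

In a functional assay on CCRF-CEM cells (Homo sapiens) for cytotoxicity, read by MTT assay, with a stated time of 72 h (on this read-out higher numbers stand for lower toxicity in this test and lower numbers for higher toxicity in this test), compound 1 gives 68800 nM. The values of compound 3 and compound 2 in this assay sit within the usual scatter of that number, so the three measured compounds are not separated from one another on this read-out; compound 1 stands within the scatter of both, with nothing to mark it out as more or less toxic than the other two.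

The next compound, compound 4, `N#C[Se]c1ccc(NC(=O)OCc2ccccc2)cc1`, has not yet been measured in this assay. It differs from compound 1 in one place: phenyl in place of ethyl on a saturated chain carbon bound to an oxygen next to a carbonyl group. The carbamate nitrogen and the selenocyanate on the shared core are kept unchanged.

Going by the values given here, no step between measured compounds isolates this particular change, and the three numbers at hand give no hint of any spread in this assay at all. The expectation is therefore a step from compound 1 to compound 4 of a 1.0-fold higher number from compound 1 to compound 4 (0.01 log units; within the scatter), that is, no change beyond the scatter in either direction. Compound 4 is estimated at 70000 nM, with a range from 35000 nM to 140000 nM.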

Compound 4, concentration lethal to 50% of the cells: 73700 nM
Compound 4: the middle estimate sits 1.1-fold (0.02 log units) below what was measured; the range from low to high includes it.
By their numbers in this assay, from the lowest: compounds 1, 3, 4 and 2 (each within the scatter of the next).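

In this assay, phenyl in place of ethyl on a saturated chain carbon bound to an oxygen next to a carbonyl group gives a 1.1-fold higher number from compound 1 to compound 4 (0.03 log units; within the scatter) and so leaves the read-out within the scatter. Going by these compounds alone, this is the only step at hand that isolates a single change, and it shows that this place accepts one six-membered aromatic ring of carbon only, with 6 heavy atoms entering and 2 leaving, without any separation between the two compounds. No measurement at hand offers an explanation for this result.

Still open, going by these compounds, is whether an amine, a carboxylic acid or a longer chain at this same place would give a step beyond the scatter, or whether this place stays as flat with such groups as it does with ethyl and phenyl. Also open, on these data alone, is whether a substituted phenyl, such as a chlorophenyl or a methoxyphenyl, on this chain carbon would give a number that separates from that of compound 4 on this read-out.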